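A few compounds are considered here, and "the series" means these few. Any claim that something is new, unique, unknown or untested is made for them only; others in the source may bear on it.

Working notes on the aryloxy series.

Three compounds have been through an ADME assay on MT4 cells (Homo sapiens) for cytotoxicity, read by MTT assay, with a stated time of 4 days; a higher number here means that more compound is tolerated, a lower number that less compound is tolerated. Compound 1 `COc1ccccc1Oc1nc(Nc2ccc(C#N)cc2)nc2ccccc12` gives 150000 nM. Compound 2 `N#Cc1ccc(Nc2nc(Oc3ccc(Cl)cc3Cl)c3ccccc3n2)cc1` gives 32000 nM. Compound 3 `Cc1cc(C#N)cc(C)c1Oc1nc(Nc2ccc(C#N)cc2)nc2ccccc12` gives 203000 nM. Compound 3 stands at the highest of the three numbers; its gap to compound 1 is within the scatter, while its gap to compound 2 is beyond it. The steps tell the same story: a 4.7-fold lower number from compound 1 to compound 2 (0.67 log units; beyond the scatter), a 1.4-fold higher number from compound 1 to compound 3 (0.13 log units; within the scatter), and a 6.3-fold higher number from compound 2 to compound 3 (0.80 log units; beyond the scatter).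

Compound 4 `N#Cc1ccc(Nc2nc(Oc3c(Cl)cc(Cl)cc3Cl)c3ccccc3n2)cc1` is the next member, not yet measured. It differs from compound 3 in one place: 2,4,6-trichlorophenyl in place of 4-cyano-2,6-dimethylphenyl on an oxygen on an aromatic ring.

Going by the values given here, of the measured steps, the one from compound 2 to compound 3 bears most directly on this change, since compound 2 carries a 2,4-dichlorophenyl on that oxygen and compound 4 a 2,4,6-trichlorophenyl, both chlorine-only rings against the cyano-dimethyl ring of compound 3. Among the compounds with values here, that step was modest and ran upward; the move from compound 3 to compound 4 runs the other way, so a modest downward step in this assay is expected, roughly a 4.1-fold lower number from compound 3 to compound 4 (0.61 log units; beyond the scatter), though the third chlorine has no measured precedent here. Compound 4 is therefore estimated at 50000 nM, with a likely range from 20000 nM to 130000 nM.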

Compound 4, half-maximal cytotoxic concentration: 56000 nM
The estimate for compound 4 lay 1.1-fold (0.05 log units) below the measured number; measured number inside the range.
By their numbers in this assay, from the lowest: compounds 2 and 4 (each within the scatter of the next); then compounds 1 and 3 (each within the scatter of the next).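

In this assay, going by these compounds alone, the chloro in place of hydrogen on an aromatic carbon gives the first single-atom change at this position, and it leaves no step beyond the scatter (a 1.8-fold higher number from compound 2 to compound 4 (0.24 log units; within the scatter)). Within the data shown here, the third chlorine therefore does not separate 2,4,6-trichlorophenyl from 2,4-dichlorophenyl in this assay, so compound 2 and compound 4 read as one level, and no compound among the four goes against that grouping. The full exchange of the ring shows that the low level is not confined to compound 2, since the trichlorophenyl ring also stands apart from the other two rings (a 3.6-fold lower number from compound 3 to compound 4 (0.56 log units; beyond the scatter); a 2.7-fold lower number from compound 1 to compound 4 (0.43 log units; beyond the scatter)), and no measurement offered here accounts for these steps.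

The 4-cyano-2,6-dimethylphenyl ring differs from the chlorine-only rings in its nitrile and its two methyl groups at once, so the compounds shown do not tell which of these parts goes with the higher number. Going by these compounds, how a ring carrying an amine or a carboxylic acid on this oxygen-linked aryl group would read in this assay also stays open.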